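A few compounds are considered here, and "the series" means these few. Any claim that something is new, unique, unknown or untested is made for them only; others in the source may bear on it.

Measured compounds:
compound 1 `O=C(/C=C/c1ccccc1O)CC(=O)/C=C/c1cccc(O)c1O` gives 34000 nM in an ADME assay on PC-12 cells (Rattus norvegicus) for cytotoxicity, read by WST assay, with a stated time of 24 h; a lower number here means that less compound is tolerated, a higher number that more compound is tolerated
compound 2 `O=C(/C=C/c1cc(O)ccc1O)CC(=O)/C=C/c1cccc(O)c1O` gives 53000 nM in this assay
compound 3 `O=C(/C=C/c1cccc(O)c1)CC(=O)c1ccc(O)c(O)c1` gives only a limit in this assay, > 100000 nM

Compound 1 and compound 2 share a core and differ by hydroxy in place of hydrogen on an aromatic carbon. That change produced a 1.6-fold higher number from compound 1 to compound 2 (0.19 log units; within the scatter). Compound 3 carries a different core; the difference between the two cores is not broken down here. For compound 3 the reading in this assay is a limit of the assay, (the limit of > 100000 nM in this assay, at which 1 of the 3 values shown sits).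

Compound 4 `O=C(/C=C/c1cc(O)ccc1O)CC(=O)c1ccc(O)c(O)c1` is not yet measured in this assay. It differs from compound 3 by hydroxy in place of hydrogen on an aromatic carbon. This is the same kind of change as that between compound 1 and compound 2, not the same: the entering hydroxy in compound 4 sits ortho to a large group, whereas in compound 2 it sits meta to a large group; in both it is para to a hydroxy group.

The step in this assay is expected to be a step that the limit leaves unreadable from compound 3 to compound 4. This expectation rests on a 1.6-fold higher number from compound 1 to compound 2 (0.19 log units; within the scatter) and on the limit of > 100000 nM in this assay, at which 1 of the 3 values shown sits, at which compound 3 sits. Compound 4 is therefore expected to give 150000 nM, estimated between 70000 nM and 320000 nM, most likely again reported as a limit.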

Compound 4, half-maximal cytotoxic concentration: > 100000 nM
Compound 4 ended at the assay's limit; the forecaster's own chance of this, stated with the estimate: 70%; the middle value is on the limit's open side.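

Compound 3 and compound 4 both read as limits in this assay, so no step can be read between them: the limit of > 100000 nM in this assay, at which 2 of the 4 values shown sit.

The compounds shown leave open whether hydroxy in place of hydrogen on an aromatic carbon changes the number at all on the core of compound 3, and how any such change compares with that between compound 1 and compound 2.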